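Amidoxime on the pyridine of the bicyclic amine

The compounds below may be only part of what the source reports. "The series", "measured", "known", "first", "only" and "open" are said of these compounds alone.

Compound 2 `c1cncc(N2CC[C@@H]3CN[C@@H]3C2)c1` gives 330 nM in a functional assay on HEK293 cells for agonist activity at Neuronal acetylcholine receptor; alpha4/beta2 (Homo sapiens), read by FLIPR (on this read-out lower numbers stand for an effect already at smaller amounts and higher numbers for an effect only at larger amounts of compound), the highest of the three numbers shown. Its mirror image, compound 1 `c1cncc(N2CC[C@H]3CN[C@H]3C2)c1`, gives 71 nM, a change of a 4.6-fold higher number from compound 1 to compound 2 (0.67 log units; beyond the scatter) that rests on (the fact that compounds 1 and 2 differ only in the configuration as drawn). Compound 3 `Clc1ccc(N2CC[C@@H]3CN[C@@H]3C2)cn1` gives 24 nM, reached by a 14-fold lower number from compound 2 to compound 3 (1.14 log units; beyond the scatter). Compound 4 `N/C(=N/O)c1cncc(N2CC[C@@H]3CN[C@@H]3C2)c1` differs from compound 2 by a group of 4 heavy atoms (1 carbon, 2 nitrogen, 1 oxygen; no ring) in place of a hydrogen atom, on an aromatic carbon. Among the compounds with values here, only one measured step bears on this change, the chloro step from compound 2 to compound 3, which was large; the entering group is different in kind, so its direction is taken as a loose guide rather than its size. Compound 4 is therefore expected to show a 2.2-fold lower number from compound 2 to compound 4 (0.34 log units; beyond the scatter), with an estimate of 150 nM and a range from 40 nM to 600 nM.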

Compound 4, half-maximal effective concentration: 180 nM
Beside the measured number, compound 4's estimate is 1.2-fold (0.08 log units) below it; low and high end bracket the measured number.
By their numbers in this assay, from the lowest: compound 3; then compound 1; then compounds 4 and 2 (each within the scatter of the next).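

In this assay, putting a group of 4 heavy atoms on this aromatic carbon, two atoms from the ring nitrogen, gives a 1.8-fold lower number from compound 2 to compound 4 (0.26 log units; within the scatter). This carbon therefore carries a group far larger than a hydrogen atom without a readable change in the number, whereas the earlier chloro step, a 14-fold lower number from compound 2 to compound 3 (1.14 log units; beyond the scatter), was large. Nothing given here accounts for this result. On these data alone, it remains open whether an amine or a carboxylic acid on this carbon would also leave the number unmoved, and how the same group behaves on the core of compound 1.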